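The source may report more compounds than this note shows. Statements on the series, on what has been measured and on what is new or still open speak of the compounds shown alone.

Measured compounds:
- Compound 1 `Oc1cccc(-c2cc(-c3cccnc3)nc(-c3cccc(Cl)c3)c2)c1`: "not determined" (no result reported) in a functional assay on T47D cells (Homo sapiens) for cytotoxicity, read by CCK-8 assay and cell counting, with a stated time of 2 days; a higher number here means a weaker inhibitor, a lower number a stronger inhibitor
- Compound 2 `Oc1cccc(-c2cc(-c3cccnc3)nc(-c3ccccc3Cl)c2)c1`: "not determined" (no result reported) in this assay
- Compound 3 `Oc1ccc(-c2cc(-c3cccnc3)nc(-c3cccc(Cl)c3)c2)cc1`: 25700 nM

Compound 1 stands without a single number in this assay; its result was not reported, and the same holds for compound 2. Within the data shown here, the only number in the set belongs to compound 3, which in this assay gives 25700 nM, a weak effect. Among the measured compounds shown here, compound 3 shares the core of compound 1 and its 3-chlorophenyl and pyridin-3-yl groups, and differs in the place of the hydroxyl on the phenyl ring; no step between the two is computed here, and nothing further can be said of that pair.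

The step that matters here leads from compound 1 to compound 4 `Oc1cccc(-c2cc(-c3ccsc3)nc(-c3cccc(Cl)c3)c2)c1`: thiophen-3-yl in place of pyridin-3-yl on an aromatic carbon. For the measured compounds named here, since compound 1 has no number, no step in this assay can be measured or sized for this change, and no direction can be read off. Going by the values given here, what remains is the single reading of compound 3, which suggests that compounds of this shape sit in the weak range.

On that footing alone, compound 4 is estimated at 20000 nM, with a range from 5000 nM to 80000 nM, and with a fair chance that this assay yields only a limit.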

Compound 4, half-maximal inhibitory concentration: 3540 nM
Beside the measured number, compound 4's estimate is 5.6-fold (0.75 log units) above it; measured number below the stated range.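

In this assay, among these compounds, compound 4 gives 3540 nM, but compound 1 carries no single number there, so no step between compound 1 and compound 4 can be read. The compounds shown leave open how thiophen-3-yl compares with pyridin-3-yl on the shared core in this assay. Nothing at hand offers an explanation for this result.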